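Diethylamino in place of piperidin-1-yl in the series

This account rests on a few compounds, and the source may have more. Where it says the series, first, only, none or still open, it means among the compounds named here.

Measured in a functional assay on MGC-803 cells (Homo sapiens) for inhibition; a lower number here means a stronger inhibitor, a higher number a weaker inhibitor:
compound 1 `O=C(CC(CC(=O)NC1Cc2ccccc2C1)c1ccc(Cl)cc1)NCCN1CCCCC1` gives 89100 nM as a number
compound 2 `O=C(CC(CC(=O)NC1Cc2ccccc2C1)c1ccc(Cl)cc1)NCCN1CCCC1` gives > 100000 nM as a limit
compound 3 `O=C(CC(CC(=O)NC1Cc2ccccc2C1)c1ccccc1)NCCN1CCCCC1` gives > 100000 nM as a limit

Compound 3 has no number and stands at the limit of > 100000 nM in this assay, at which 2 of the 3 values shown sit, as a limit only. Compound 4 `CCN(CC)CCNC(=O)CC(CC(=O)NC1Cc2ccccc2C1)c1ccccc1` carries diethylamino in place of piperidin-1-yl on a saturated chain carbon, two bonds along the chain from an amide-type nitrogen. The closest measured step also changes this amine (an at least 1.1-fold higher number from compound 1 to compound 2 (0.05 log units; that floor lies within the scatter)) but starts from the chloro compound. Among the compounds with values here, the other measured step (an at least 1.1-fold higher number from compound 1 to compound 3 (0.05 log units; that floor lies within the scatter)) is the one that leads to compound 3 and changes a different place. Both steps are floors set by a limit, so neither gives a true size. Within the data shown here, the only number in the set belongs to compound 1 (89100 nM), and compound 4 lacks its chloro group. No step beyond the scatter is therefore expected in this assay, and a further limit is the likeliest report. The expected step is small (a number no higher from compound 3 to compound 4 (the limit leaves the size open)) and stays within the scatter. For compound 4 the estimated value is 100000 nM (range 50000 nM to 200000 nM) in this read-out.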

Compound 4, half-maximal inhibitory concentration: > 100000 nM
Compound 4: a limit, no number; the forecaster's own chance of this, stated with the estimate: 75%; the middle value lies on the limit itself.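

In this assay no step can be read from compound 3 to compound 4, as both stand only at a limit: the limit of > 100000 nM in this assay, at which 3 of the 4 values shown sit. Left open is whether in this assay diethylamino in place of piperidin-1-yl changes the number at all.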